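This account rests on a few compounds, and the source may have more. Where it says the series, first, only, none or still open, it means among the compounds named here.

Compound 1 `O=c1ccoc2cc(OCc3cn(Cc4ccccc4)nn3)ccc12` is the plainest member of this small set, carrying an unsubstituted benzyl group on the shared core. In a functional assay on SW480 cells (Homo sapiens) for cytotoxicity, read by MTT assay, with a stated time of 48 h (on this read-out higher numbers stand for weaker inhibition and lower numbers for stronger inhibition), compound 1 gives 42900 nM. Compound 2 `O=c1ccoc2cc(OCc3cn(Cc4ccc(Cl)cc4)nn3)ccc12` bears a 4-chlorobenzyl group instead. For compound 2 this assay reports only a limit, > 100000 nM. Compound 3 `O=c1ccoc2cc(OCc3cn(Cc4cccc(Br)c4)nn3)ccc12` carries a 3-bromobenzyl group. For compound 3 as well this assay reports only a limit, > 100000 nM. Measured from the unsubstituted parent, the two halogen steps are an at least 2.3-fold higher number from compound 1 to compound 2 (0.36 log units; beyond the scatter) and an at least 2.3-fold higher number from compound 1 to compound 3 (0.36 log units; beyond the scatter). Between the two halogenated compounds the step is a step that the two limits leave unreadable from compound 2 to compound 3, because both values sit at the limit of > 100000 nM in this assay, at which 2 of the 3 values shown sit.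

Compound 4 `O=c1ccoc2cc(OCc3cn(Cc4ccc(F)cc4)nn3)ccc12` is the 4-fluorobenzyl analogue. Its difference from compound 2 is fluoro in place of chloro on an aromatic carbon. Within the data shown here, the steps that bear on this change are the two from compound 1, both of which moved beyond the scatter toward weaker inhibition on adding a halogen, while compound 2 itself offers no number to start from. Without a measured step for a fluoro group, the step is expected to be small or none beyond the scatter, and is estimated as an at least 1.3-fold lower number from compound 2 to compound 4 (0.12 log units; that floor lies within the scatter). In this assay compound 4 is therefore estimated at 75000 nM, with a range from 25000 nM to 220000 nM.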

Compound 4, half-maximal inhibitory concentration: 11200 nM
Beside the measured number, compound 4's estimate is 6.7-fold (0.83 log units) above it; measured number below the stated range.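

A halogen on this aromatic carbon does not by itself weaken inhibition in this assay: the fluoro group gives a 3.8-fold lower number from compound 1 to compound 4 (0.58 log units; beyond the scatter), which runs opposite to the steps seen on adding chloro or bromo. Exchanging chloro for fluoro, a swap of one heavy atom for one heavy atom para to a large group, is an at least 8.9-fold lower number from compound 2 to compound 4 (0.95 log units; beyond the scatter), and replacing the 3-bromophenyl group with the 4-fluorophenyl group is an at least 8.9-fold lower number from compound 3 to compound 4 (0.95 log units; beyond the scatter). The true sizes of these two steps cannot be fixed and only their floors can be given, because each of them starts from a limit: the limit of > 100000 nM in this assay, at which 2 of the 4 values shown sit.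

With compound 4 the only halogenated compound that has a number, and with the bromo group of compound 3 sitting at a different place on the ring from the chloro group of compound 2 and the fluoro group of compound 4, the shown compounds do not separate the kind of halogen from its place. Going by these compounds, it also remains open how a methoxy group or an amine at the same carbon would compare with the fluoro group of compound 4.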